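A few compounds are considered here, and "the series" means these few. Any claim that something is new, unique, unknown or untested is made for them only; others in the source may bear on it.

Measured so far in an assay on isolated protein with Bile acid receptor (Homo sapiens) as the target; on this read-out higher numbers stand for an effect only at larger amounts of compound and lower numbers for an effect already at smaller amounts:
compound 1 `COC(=O)/C=C/c1ccc(CN(C(=O)C2CCCCC2)c2cccc(/C=C/C(=O)OC)c2)cc1`: > 1000 nM
compound 2 `COC(=O)/C=C/c1cccc(N(Cc2ccc(/C=C/C(=O)OCc3ccccc3)cc2)C(=O)C2CCCCC2)c1`: > 1000 nM

The value of compound 1 is a limit of this assay, not a number. The value of compound 2 is likewise a limit, so compound 2 stands only at the limit of > 1000 nM in this assay, at which 2 of the 2 values shown sit, and has no number of its own. Among the measured compounds shown here, the single measured step, a step that the two limits leave unreadable from compound 1 to compound 2, is one the two limits leave unreadable, and no size can be taken from it.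

Compound 3 `COC(=O)/C=C/c1cccc(N(Cc2ccc(/C=C/c3c(Cl)cccc3Cl)cc2)C(=O)C2CCCCC2)c1` differs from compound 2 by 2,6-dichlorophenyl in place of benzyloxycarbonyl on a double-bonded chain carbon bound to a double-bonded chain carbon. For the measured compounds named here, no measured step bears on this change: the only step is unreadable, and every value shown sits at the same limit. For this assay, therefore, neither a direction nor a size of step can be expected from the data. The step expected is a step that the limit leaves unreadable from compound 2 to compound 3. For compound 3 the estimate is 2000 nM, with a range from 300 nM to 10000 nM. A limit reading rather than a number is again likely.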

Compound 3, half-maximal effective concentration: 150 nM
For compound 3 the middle estimate is 13-fold (1.12 log units) above the measured one; measured number outside the range, below it.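

In this assay the 2,6-dichlorophenyl group on this double-bonded chain carbon gives an at least 6.6-fold lower number from compound 2 to compound 3 (0.82 log units; beyond the scatter) against benzyloxycarbonyl and an at least 6.6-fold lower number from compound 1 to compound 3 (0.82 log units; beyond the scatter) against methoxycarbonyl. Among the compounds shown here, the step from compound 1 to compound 2 cannot be read, so these are the first steps that show this position responding to a change. Both are bounds rather than sizes, because compound 1 and compound 2 carry limits and not numbers: the limit of > 1000 nM in this assay, at which 2 of the 3 values shown sit.

From the compounds shown here alone, whether the lower number needs both chlorines remains open, as an unsubstituted phenyl or a 2-chlorophenyl group at this carbon would be needed to separate the ring from its chlorine atoms. Also open, going by these compounds, is how a carboxylic acid in place of the methoxycarbonyl group that compound 3 keeps would read.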